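This account rests on a few compounds, and the source may have more. Where it says the series, first, only, none or still open, it means among the compounds named here.

Measured so far: compound 1 `Cc1cccc(-n2cc(COC(=O)c3cc4ccccc4[nH]3)nn2)c1C` with 15300 nM in an ADME assay on HEK293 cells (Homo sapiens) for cytotoxicity, read by MTT assay, with a stated time of 48 h; on this read-out lower numbers stand for stronger inhibition and higher numbers for weaker inhibition; compound 2 `COc1ccc(-n2cc(COC(=O)c3cc4ccccc4[nH]3)nn2)cc1` with 42500 nM.

Compound 2 holds the highest of the two numbers in this assay; its nearest neighbour is compound 1, reached by a 2.8-fold higher number from compound 1 to compound 2 (0.44 log units; beyond the scatter). Compound 3 `O=C(OCc1cn(-c2ccccc2Br)nn1)c1cc2ccccc2[nH]1` differs from compound 2 by 2-bromophenyl in place of 4-methoxyphenyl on an aromatic nitrogen. Among the compounds with values here, only the step from compound 1 to compound 2 bears on this change, and it was modest. For compound 3 a modest move toward a lower number is therefore expected, as a 2.1-fold lower number from compound 2 to compound 3 (0.33 log units; beyond the scatter). Compound 3 is accordingly estimated at 20000 nM, within a range of 8000 nM to 50000 nM.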

Compound 3, half-maximal inhibitory concentration: > 200000 nM
Compound 3: no number, only a limit (the forecaster's own chance of this, stated with the estimate: 10%); middle value at least 10-fold (1.00 log units) away from the limit.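

Compound 3 reads only as a limit, not as a number: the limit of > 200000 nM in this assay, at which 1 of the 3 values shown sits. The group on the aromatic nitrogen therefore shifts the read-out much further than the earlier pair showed, with an at least 4.7-fold higher number from compound 2 to compound 3 (0.67 log units; beyond the scatter) and an at least 13-fold higher number from compound 1 to compound 3 (1.11 log units; beyond the scatter). Compound 1 also carries a group on its phenyl next to the ring nitrogen, yet it gives a measured number, so that place alone does not set the limit.

From the compounds shown here alone, it remains open whether the bromine itself drives this step, and how a phenyl carrying an amine or a carboxylic acid would read here.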